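A few compounds are considered here, and "the series" means these few. Any claim that something is new, unique, unknown or untested is made for them only; others in the source may bear on it.

In an ADME assay on Huh-7 cells (Homo sapiens) for cytotoxicity, with a stated time of 72 h (on this read-out higher numbers stand for lower toxicity in this test and lower numbers for higher toxicity in this test), three compounds that share one core have been tested. Compound 1 `CC(C)CCN1C(=O)C(C2=NS(=O)(=O)c3cc(NS(C)(=O)=O)ccc3N2)=C(O)[C@H]2CCC[C@H]21` gives > 1000 nM, which is a limit of this assay rather than a number. Compound 3 `CS(=O)(=O)Nc1ccc2c(c1)S(=O)(=O)N=C(c1c(O)c3cccn3n(Cc3ccc(F)cc3)c1=O)N2` also gives a limit, > 1000 nM. Compound 2 `CS(=O)(=O)Nc1ccc2c(c1)S(=O)(=O)N=C(C1=C(O)C3CCCC3N(C3CCCCC3)C1=O)N2` gives > 10000 nM, again a limit. Compound 2 therefore sits at the limit of > 10000 nM in this assay, at which 1 of the 3 values shown sits. The two other compounds sit at the limit of > 1000 nM in this assay, at which 2 of the 3 values shown sit. Compound 4 `CS(=O)(=O)Nc1ccc2c(c1)S(=O)(=O)N=C(C1=C(O)C3CCCC3N(Cc3ccccc3)C1=O)N2` has not yet been measured; it differs from compound 2 by benzyl in place of cyclohexyl on an amide-type nitrogen in a ring. Among the compounds with values here, no measured pair differs in one place, so no step size is known from the data. The expected step is a number no higher from compound 2 to compound 4 (the limit leaves the size open), nothing beyond the usual scatter. Compound 4 is estimated at 10000 nM, with a range from 3000 nM to 30000 nM, and a limit is the likely report.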

Compound 4, half-maximal cytotoxic concentration: > 33000 nM
Compound 4: no number, only a limit; the forecaster's own chance of this, stated with the estimate: 80%; middle value at least 3.3-fold (0.51 log units) from the limit.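

Compound 2 and compound 4 both give only limits in this assay, and the step between them, benzyl in place of cyclohexyl, cannot be read. The compounds shown leave open the concentration at which any of them turns toxic.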